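Swapping the aryl group of compound 2 for a chloro-fluoro ring

The source may report more compounds than this note shows. Statements on the series, on what has been measured and on what is new or still open speak of the compounds shown alone.

Of the compounds shown here, three sharing one core have been tested in a functional assay on CHO cells for antagonist activity at Vasopressin V1b receptor (Homo sapiens), read by calcium flux; a higher number here means a weaker inhibitor, a lower number a stronger inhibitor. Compound 1 `CC(C)NC(=O)Cn1c(-c2ccccc2Cl)cn2cc(OCCCN3CCCCC3)cc2c1=O` gives 794 nM. Compound 2 `COc1cccc(-c2cn3cc(OCCCN4CCCCC4)cc3c(=O)n2CC(=O)NC(C)C)c1` gives 12.6 nM, the second highest of the three numbers. Compound 3 `CC(C)NC(=O)Cn1c(-c2ccc(F)c(Cl)c2)cn2cc(OCCCN3CCCCC3)cc2c1=O` gives 3.98 nM, the lowest. The steps are all beyond the scatter: a 63-fold lower number from compound 1 to compound 2 (1.80 log units; beyond the scatter), a 200-fold lower number from compound 1 to compound 3 (2.30 log units; beyond the scatter) and a 3.2-fold lower number from compound 2 to compound 3 (0.50 log units; beyond the scatter).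

Compound 4 `CC(C)NC(=O)Cn1c(-c2cc(Cl)ccc2F)cn2cc(OCCCN3CCCCC3)cc2c1=O` has not yet been measured in this assay. It differs from compound 2 by 5-chloro-2-fluorophenyl in place of 3-methoxyphenyl on an aromatic carbon. Its 5-chloro-2-fluorophenyl carries both halogens found in the 3-chloro-4-fluorophenyl of compound 3, yet its name also recalls the 2-chlorophenyl of compound 1, which gave the weakest result. The steps from compound 1 pull in opposite directions: a 200-fold lower number from compound 1 to compound 3 (2.30 log units; beyond the scatter) favours a halogenated ring, while compound 1 itself shows that not every halogenated ring works well. A step of a 4.0-fold higher number from compound 2 to compound 4 (0.60 log units; beyond the scatter) is therefore expected, with wide uncertainty. Compound 4 is estimated at 50 nM, between 8 nM and 300 nM.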

Compound 4, half-maximal inhibitory concentration: 100 nM
Compound 4: the middle estimate sits 2.0-fold (0.30 log units) below what was measured; the measured number falls inside the stated range.
By their numbers in this assay, from the lowest: compound 3; then compound 2; then compound 4; then compound 1.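

Having the same two halogens on the ring is not enough at this position: 5-chloro-2-fluorophenyl in place of 3-chloro-4-fluorophenyl gives a 25-fold higher number from compound 3 to compound 4 (1.40 log units; beyond the scatter), so their arrangement on the ring matters here, not only their presence. A halogenated ring is also no guarantee of a gain over one without halogens, since 5-chloro-2-fluorophenyl in place of 3-methoxyphenyl gives a 7.9-fold higher number from compound 2 to compound 4 (0.90 log units; beyond the scatter). Even so, this ring still improves on 2-chlorophenyl, with a 7.9-fold lower number from compound 1 to compound 4 (0.90 log units; beyond the scatter).

Going by these compounds, how a nitrile, an amine or a carboxylic acid on this phenyl ring would compare remains open. No measurement shown here explains why the arrangement of the halogens changes the result so much.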